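Hydrazide to thiosemicarbazide on the shared core

A few compounds are considered here, and "the series" means these few. Any claim that something is new, unique, unknown or untested is made for them only; others in the source may bear on it.

Among the compounds with values here, in a functional assay on the whole organism for inhibition, with Mus musculus as the target, read by paw edema, with a stated time of 180 min, at a dose of 200 mg/kg by the oral route (on this read-out higher numbers stand for a stronger effect at the one dose given and lower numbers for a weaker effect), compound 2 `Cc1ccc2oc(=O)n(CC(=O)NN)c2c1` gives 70.5%, the highest of the two numbers measured so far. Compound 1 `CCn1c(Cn2c(=O)oc3ccc(C)cc32)n[nH]c1=S` gives 31.8% in this assay, lower beyond the scatter. Within the data shown here, no measured pair differs in a single place, so no step size is known from the data. Compound 3 `CNC(=S)NNC(=O)Cn1c(=O)oc2ccc(C)cc21` differs from compound 2 by a group of 4 heavy atoms (2 carbon, 1 nitrogen, 1 sulfur; no ring) in place of a hydrogen atom, on an amine nitrogen. The expected step is a number 12.5 percentage points lower from compound 2 to compound 3 (beyond the scatter), a modest decrease lying at the edge of the scatter. Compound 3 is estimated at 58% in this assay, with a range of 38% to 75%.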

Compound 3, a percentage reported as inhibition, in the whole organism at one dose (the size of the read-out at that dose, not a potency): 71.6%
Compound 3: middle estimate off by 13.6 percentage points, on the low side; low and high end bracket the measured number.
By their numbers in this assay, from the lowest: compound 1; then compounds 2 and 3 (each within the scatter of the next).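

On the amine nitrogen whose other neighbour is an amide-type nitrogen, replacing a hydrogen atom with the group of 4 heavy atoms gives a step in this assay of a number 1.1 percentage points higher from compound 2 to compound 3 (within the scatter). This position therefore accepts a sizeable acyclic group with no change in the read-out beyond the scatter at the one dose given. Nothing available explains this result.

On these data alone, whether a plain methyl group, an acetyl group or a longer alkyl chain on this nitrogen fits the same picture remains open. So does whether the sulfur of the entering group can give way to oxygen.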